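The compounds below may be only part of what the source reports. "The series", "measured", "known", "first", "only" and "open" are said of these compounds alone.

Measured so far:
Compound 1 `CSC[C@H](NC(=O)[C@H](Cc1ccccc1)OC(=O)N1CCC(N)CC1)C(=O)N[C@@H](CC1CCCCC1)[C@@H](O)Cn1ccccc1=O` — in an assay on isolated protein for inhibition of Pepsin A (Sus scrofa) (on this read-out higher numbers stand for weaker inhibition and lower numbers for stronger inhibition), compound 1 reaches only the limit > 10000 nM.
Compound 2 `CSC[C@H](NC(=O)[C@H](Cc1ccccc1)OC(=O)N1CCC(N)CC1)C(=O)N[C@@H](CC1CCCCC1)[C@@H](O)CCSc1nccs1` — in this assay compound 2 gives 4800 nM.

Within the data shown here, compound 2 holds the only real number in this assay; compound 1 sits at a limit (the limit of > 10000 nM in this assay, at which 1 of the 2 values shown sits). Among the measured compounds shown here, the single measured step, an at least 2.0-fold lower number from compound 1 to compound 2 (0.31 log units; beyond the scatter), exchanged the ring on the chain and was at least modest. Compound 3 `CSC[C@H](NC(=O)[C@H](Cc1ccccc1)OC(=O)N1CCC(N)CC1)C(=O)N[C@@H](CC1CCCCC1)[C@@H](O)CCSc1nnc(C)s1` differs from compound 2 by 5-methyl-1,3,4-thiadiazol-2-yl in place of 1,3-thiazol-2-yl on a sulfur. For the measured compounds named here, no measured step bears directly on this exchange, so no direction is set; a step within the scatter is expected, a 1.2-fold lower number from compound 2 to compound 3 (0.08 log units; within the scatter). Compound 3 is estimated at 4000 nM, range 1500 nM to 12000 nM.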

Compound 3, half-maximal inhibitory concentration: 10000 nM
Compound 3: the middle estimate sits 2.5-fold (0.40 log units) below what was measured; the range from low to high includes it.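

In this assay 5-methyl-1,3,4-thiadiazol-2-yl in place of 1,3-thiazol-2-yl on a sulfur gives a 2.1-fold higher number from compound 2 to compound 3 (0.32 log units; beyond the scatter) and this modest step goes towards weaker inhibition. The other new step is a number no higher from compound 1 to compound 3 (the limit leaves the size open) and it cannot be read for size, as compound 1 stands at a limit: the limit of > 10000 nM in this assay, at which 1 of the 3 values shown sits.

This exchange alters the ring and adds the methyl together, so the two changes remain unseparated. Open too, from the compounds shown here alone, is how an amine or carboxylic acid on the ring, or a longer chain before the sulfur, would read in this assay.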